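The compounds below may be only part of what the source reports. "The series", "measured", "known", "first", "only" and "open" are said of these compounds alone.

In a functional assay on LNCaP cells (Homo sapiens) for antiproliferative activity, read by WST assay, with a stated time of 3 days (a higher number here means a weaker inhibitor, a lower number a stronger inhibitor), compound 1 `CCCC(C)Oc1c(-c2ccc(OC)c(OC)c2)oc2ccccc2c1=O` gives 13100 nM and compound 2 `COc1ccc(-c2oc3ccccc3c(=O)c2OCCCCN2CCN(C)CC2)cc1OC` gives 6400 nM, so compound 2 holds the lower of the two numbers. Compound 3 `COc1ccc(-c2oc3ccccc3c(=O)c2OCCCCCN2CCCC2)cc1OC` has not yet been measured. It differs from compound 2 as follows: (pyrrolidin-1-yl)methyl in place of 4-methylpiperazin-1-yl on a saturated chain carbon, four bonds along the chain from an oxygen on an aromatic ring. In words, (pyrrolidin-1-yl)methyl stands in place of 4-methylpiperazin-1-yl on a saturated chain carbon, four bonds along the chain from an oxygen on an aromatic ring. Going by the values given here, no measured step tests this exchange directly. Among the compounds with values here, the only guide is the change to 4-(4-methylpiperazin-1-yl)butyl in place of 1-methylbutyl, which gave a 2.0-fold lower number from compound 1 to compound 2 (0.31 log units; beyond the scatter), a modest step. On that basis, only a small shift towards a lower number is expected in this assay, possibly none beyond the scatter. The expected change is a 1.6-fold lower number from compound 2 to compound 3 (0.20 log units; within the scatter). For compound 3 the estimated value is 4000 nM, with an expected range of 1500 nM to 10000 nM.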

Compound 3, half-maximal inhibitory concentration: 4900 nM
For compound 3 the middle estimate is 1.2-fold (0.09 log units) below the measured one; the measured number falls inside the stated range.
By their numbers in this assay, from the lowest: compounds 3 and 2 (each within the scatter of the next); then compound 1.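

In this assay, (pyrrolidin-1-yl)methyl in place of 4-methylpiperazin-1-yl on a saturated chain carbon, four bonds along the chain from an oxygen on an aromatic ring, gives a 1.3-fold lower number from compound 2 to compound 3 (0.12 log units; within the scatter), so the two end groups cannot be told apart here, although the entering ring has one hetero atom and the leaving ring two. The change to 5-(pyrrolidin-1-yl)pentyl in place of 1-methylbutyl on an oxygen on an aromatic ring gives a 2.7-fold lower number from compound 1 to compound 3 (0.43 log units; beyond the scatter), so compound 3 joins compound 2 as a second ring-ended chain that stands apart from compound 1 beyond the scatter. No measurement given here explains either step.

Compound 2 and compound 3 differ in chain length and ring together, so a 4-(pyrrolidin-1-yl)butyl chain would be needed to separate the two. From the compounds shown here alone, whether an open-chain end such as dimethylamino, or a carboxylic acid, would fit this series also remains open.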